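The compounds below may be only part of what the source reports. "The series", "measured", "known", "first", "only" and "open" are said of these compounds alone.

Compound 1 `COC1CN(C(=O)/C=C/c2ccncc2-c2ccc3ccccc3c2)C1` gives > 30000 nM in a functional assay on HCT-116 cells (Homo sapiens) for inhibition, read by MTT assay, with a stated time of 72 h (a higher number here means a weaker inhibitor of growth, a lower number a stronger inhibitor of growth), which is a limit of the assay and not a number. Compound 2 `CNC(=O)COc1ccncc1-c1ccc2ccccc2c1` gives "not determined" (no result reported) in this assay. Compound 3 `CN1CCN(C(=O)/C=C/c2ccncc2-c2ccc3ccccc3c2)CC1` gives > 30000 nM in this assay, again a limit of the assay.

Among the compounds with values here, compound 3 therefore stands only at a limit, and the one step that touches it, a step that the two limits leave unreadable from compound 1 to compound 3, cannot be sized because both ends sit at the limit of > 30000 nM in this assay, at which 2 of the 3 values shown sit. Compound 4 `CN(C)C(=O)/C=C/c1ccncc1-c1ccc2ccccc2c1` differs from compound 3 by dimethylamino in place of 4-methylpiperazin-1-yl on a carbonyl carbon. Within the data shown here, no measured step gives a readable size for this kind of change, so the step that the limit leaves unreadable from compound 3 to compound 4 is expected to be none that can be told from the scatter. Compound 4 is expected to give about 40000 nM, between 15000 nM and 150000 nM, most likely again as a limit.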

Compound 4, concentration for 50% growth inhibition: 4540 nM
For compound 4 the middle estimate is 8.8-fold (0.95 log units) above the measured one; measured number below the stated range.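

Dimethylamino on the carbonyl carbon gives the first reading off the limit in this assay, with an at least 6.6-fold lower number from compound 3 to compound 4 (0.82 log units; beyond the scatter) and an at least 6.6-fold lower number from compound 1 to compound 4 (0.82 log units; beyond the scatter). This shows that the group at this position can change growth inhibition, which compound 1 and compound 3 could not show, each resting only on a limit of the assay: the limit of > 30000 nM in this assay, at which 2 of the 4 values shown sit.

The compounds shown leave open whether the step depends on losing the ring or on the lower count of heavy atoms. A diethylamino or pyrrolidin-1-yl group on this carbonyl carbon would bear on that question.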